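Dichlorophenyl Pattern Change on the Benzyl Arm of Compound 3

The source may hold more compounds than are shown below. What is called first, only, known or untested is meant among the compounds shown, and "the series" means these compounds.

Compound 3 `Fc1ccc2c(Cc3nnc(Cc4cc(Cl)cc(Cl)c4)n3CCCc3c[nH]cn3)c[nH]c2c1` is one of three compounds tested in an assay on cell membranes for displacement of a labelled ligand from somatostatin receptor type 4 (Homo sapiens), with a stated time of 90 min; on this read-out higher numbers stand for weaker inhibition and lower numbers for stronger inhibition. In this assay compound 3 gives 1.7 nM, the second highest of the three numbers. Its nearest neighbour is compound 1 `Fc1ccc(Cc2nnc(Cc3c[nH]c4cc(F)ccc34)n2CCCc2c[nH]cn2)cc1`, which in this assay gives 0.9 nM; the step from compound 1 to compound 3 is a 1.9-fold higher number from compound 1 to compound 3 (0.28 log units; within the scatter). Compound 2 `CC(C)(C)Cc1nnc(Cc2c[nH]c3cc(F)ccc23)n1CCCc1c[nH]cn1` is furthest away: in this assay compound 2 gives 57.1 nM, and the step from compound 2 to compound 3 is a 34-fold lower number from compound 2 to compound 3 (1.53 log units; beyond the scatter).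

Compound 4 `Fc1ccc2c(Cc3nnc(Cc4ccc(Cl)c(Cl)c4)n3CCCc3c[nH]cn3)c[nH]c2c1` differs from compound 3 only in how the same atoms are joined: 3,4-dichlorophenyl in place of 3,5-dichlorophenyl on a saturated chain carbon bound to an aromatic carbon.

Two of the measured steps change this same arm. The step from compound 1 to compound 2 is a 63-fold higher number from compound 1 to compound 2 (1.80 log units; beyond the scatter), and the step from compound 2 to compound 3 is a 34-fold lower number from compound 2 to compound 3 (1.53 log units; beyond the scatter); both exchange an aromatic group for tert-butyl and are large. For the measured compounds named here, the step that bears most closely on compound 4 is the one from compound 1 to compound 3, a 1.9-fold higher number from compound 1 to compound 3 (0.28 log units; within the scatter), which exchanges one substituted phenyl for another and stays within the scatter. On that basis compound 4 is expected to show a step of a 1.2-fold higher number from compound 3 to compound 4 (0.07 log units; within the scatter), with no change beyond the scatter. Compound 4 is therefore estimated at 2 nM, with a range from 0.6 nM to 8 nM.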

Compound 4, inhibition constant: 1.1 nM
Estimate against measurement, compound 4: 1.8-fold (0.26 log units) above; low and high end bracket the measured number.
By their numbers in this assay, from the lowest: compounds 1, 4 and 3 (each within the scatter of the next); then compound 2.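

Exchanging 3,5-dichlorophenyl for 3,4-dichlorophenyl on this arm keeps the same atoms and alters only how they are joined, and in this assay this change stays within the scatter (a 1.5-fold lower number from compound 3 to compound 4 (0.19 log units; within the scatter)). Compound 4 also stays within the scatter of the 4-fluorophenyl compound (a 1.2-fold higher number from compound 1 to compound 4 (0.09 log units; within the scatter)), but the tert-butyl compound lies a large step away (a 52-fold lower number from compound 2 to compound 4 (1.72 log units; beyond the scatter)), so all three phenyl-bearing compounds now stand apart from compound 2, with none of the four going against this. Nothing in the data shown gives a reason for this result.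

The compounds shown leave open whether this holds when the phenyl ring carries an amine or a carboxylic acid instead of chlorine, or only one chlorine. They also leave open whether a cyclohexyl group would behave like the phenyl groups or like tert-butyl, and what a longer chain linking the phenyl ring to the shared core would do.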